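Two Aryl Substituents and Growth Inhibition at One Concentration

The source may report more compounds than this note shows. Statements on the series, on what has been measured and on what is new or still open speak of the compounds shown alone.

Compound 1 `COc1ccc(-c2nc3sc(-c4ccccc4)cn3n2)cc1` gives 40%
Compound 2 `CC(=O)c1ccc(NC(=O)Cn2nc(C(F)(F)F)nc2N)cc1` gives 7.42%
Compound 3 `Clc1ccc(-c2cn3nc(-c4ccccc4)nc3s2)cc1` gives 40%

In a functional assay on Hs-578T cells (Homo sapiens) for inhibition, read by sulforhodamine B assay, with a stated time of 48 h, tested at 10 uM (a lower number here means less inhibition of growth, a higher number more inhibition of growth at the concentration tested), compound 3 gives 40% and so stands level with compound 1 within the usual scatter, while compound 2 at 7.42% lies lower, beyond that scatter. Compound 4 `COc1ccc(-c2nc3sc(-c4ccc(Cl)cc4)cn3n2)cc1` follows from compound 3 by a single change methoxy in place of hydrogen on an aromatic carbon in which methoxy takes the place of hydrogen on an aromatic carbon. Going by the values given here, no two measured compounds differ in only one place, so the data hold no direct step for this change. The nearest guide is compound 1, which also carries a methoxy group and gives 40% in this assay without standing apart from compound 3. On that evidence, no step beyond the scatter is expected in either direction, although this remains a thin basis for any forecast. The estimated step of a number 2 percentage points higher from compound 3 to compound 4 (within the scatter) is expected to stay within the scatter. For compound 4 the expected value is 42% with an estimated range from 24% to 60% when it is measured.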

Compound 4, percent growth inhibition at one concentration: 73%
Compound 4: middle estimate off by 31 percentage points, on the low side; the measured number lies above the stated range.
By their numbers in this assay, from the lowest: compound 2; then compounds 1 and 3 (each within the scatter of the next); then compound 4.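

In this assay, going by these compounds alone, methoxy in place of hydrogen on an aromatic carbon, para to a large group, gives a number 33 percentage points higher from compound 3 to compound 4 (beyond the scatter), the first readable step at this position and one that is seen with the chloro group already present on the other aryl ring. The reverse comparison points the same way: chloro in place of hydrogen on an aromatic carbon gives a number 33 percentage points higher from compound 1 to compound 4 (beyond the scatter), so each of the two groups raises the number when the other is already in place, and compound 4 is the only compound shown that carries both. Nothing at hand accounts for either step, and the size of each can be stated only for this pair of groups on the shared core.

The compounds shown leave open whether either group would produce a step of this size without the other, since none of them has hydrogen at both positions. They also leave open whether the step belongs to methoxy itself or would also appear with an amine, a hydroxyl or a longer chain such as ethoxy at this position, or with fluoro or bromo in place of chloro.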